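The compounds below may be only part of what the source reports. "The series", "measured", "known", "first", "only" and "open" are said of these compounds alone.

Measured so far in a functional assay on the whole organism for inhibition, with Rattus norvegicus as the target, read by paw edema, with stated times of 30 min and 2 h, at a dose of 0.28 mmol/kg by the oral route; on this read-out lower numbers stand for less inhibition and higher numbers for more inhibition at the one dose given (going by the name of the read-out):
- compound 1, `CCNC(=O)c1nc(-c2cc(OC)c(OC)c(OC)c2)n(-c2ccc(OC)cc2)n1`: 68%
- compound 2, `COc1ccc(-n2nc(C(=O)Nc3ccccc3C)nc2-c2cc(OC)c(OC)c(OC)c2)cc1`: 30%

Going by the values given here, compound 2 stands lowest of the two numbers; the only neighbour is compound 1, and the step between them, a number 38 percentage points lower from compound 1 to compound 2 (beyond the scatter), is beyond the scatter.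

Compound 3, `COc1ccc(-n2nc(C(=O)Nc3ccc(C(F)(F)F)cc3)nc2-c2cc(OC)c(OC)c(OC)c2)cc1`, has not been measured. It differs from compound 2 by 4-(trifluoromethyl)phenyl in place of 2-methylphenyl on an amide-type nitrogen. Among the compounds with values here, the one measured step, a number 38 percentage points lower from compound 1 to compound 2 (beyond the scatter), exchanges ethyl for 2-methylphenyl on the amide-type nitrogen, so it bears on the present change only loosely: it shows that a six-membered aromatic ring of carbon only at that place gave a lower number than ethyl, but no measured pair compares one such ring with another. Compound 3 keeps a six-membered aromatic ring of carbon only at the amide-type nitrogen, as compound 2 does, so the step expected for a number 3 percentage points higher from compound 2 to compound 3 (within the scatter) is none beyond the scatter, with the direction undetermined. Compound 3 is therefore estimated at 33% in this assay, with a range of 12% to 56%.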

Compound 3, a percentage reported as inhibition, in the whole organism at one dose (the size of the read-out at that dose, not a potency): 55%
Beside the measured number, compound 3's estimate is 22 percentage points below it; measured number inside the range.
By their numbers in this assay, from the lowest: compound 2; then compound 3; then compound 1.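

In this assay the choice of aromatic ring on the amide-type nitrogen matters: a number 25 percentage points higher from compound 2 to compound 3 (beyond the scatter) with 4-(trifluoromethyl)phenyl in place of 2-methylphenyl, although each group has one six-membered aromatic ring of carbon only. Ethyl still gives the highest number of the three, as 4-(trifluoromethyl)phenyl in place of ethyl gives a number 13 percentage points lower from compound 1 to compound 3 (beyond the scatter) and so does not recover the whole gap, but this step is smaller than the one to compound 2, so the loss relative to ethyl differs with the ring in these two compounds. Nothing measured on these compounds accounts for the gap between the two rings.

The two rings differ both in the group they carry and in where it sits, so the compounds shown cannot separate these two changes, and an unsubstituted phenyl on the same nitrogen would give a reference for both. Going by these compounds, how a longer chain such as butyl, or a saturated ring such as cyclohexyl, would compare with ethyl at this place also remains open.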